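Moving the methoxy group on the triazole-linked phenyl ring

A few compounds are considered here, and "the series" means these few. Any claim that something is new, unique, unknown or untested is made for them only; others in the source may bear on it.

Measured so far:
compound 1, `CC(C)(C)c1cn(C[C@H](O)[C@H]2OC(=O)C(OCc3ccccc3)=C2OCc2ccccc2)nn1`: 18300 nM
compound 2, `O=C1O[C@H]([C@@H](O)Cn2cc(CNS(=O)(=O)c3ccc(F)cc3)nn2)C(OCc2ccccc2)=C1OCc1ccccc1`: 25000 nM
compound 3, `COc1ccc(-c2cn(C[C@H](O)[C@H]3OC(=O)C(OCc4ccccc4)=C3OCc3ccccc3)nn2)cc1`: 16400 nM

All three compounds share one core and differ only in the group attached to an aromatic carbon of the five-membered ring with three nitrogens. They were tested in a functional assay on HeLa cells (Homo sapiens) for antiproliferative activity, read by MTT assay, with a stated time of 72 h; a lower number here means a stronger inhibitor, a higher number a weaker inhibitor. Compound 3 gives the lowest of the three numbers, but the two steps leading to it, a 1.1-fold lower number from compound 1 to compound 3 (0.05 log units; within the scatter) and a 1.5-fold lower number from compound 2 to compound 3 (0.18 log units; within the scatter), both stay within the scatter, so none of the three can be set apart from the others. The step from compound 1 to compound 2 is likewise small: a 1.4-fold higher number from compound 1 to compound 2 (0.14 log units; within the scatter).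

Compound 4, `COc1ccccc1-c1cn(C[C@H](O)[C@H]2OC(=O)C(OCc3ccccc3)=C2OCc2ccccc2)nn1`, carries a 2-methoxyphenyl group where compound 3 carries a 4-methoxyphenyl group: 2-methoxyphenyl in place of 4-methoxyphenyl on an aromatic carbon. For the measured compounds named here, no measured step moves the methoxy group around its ring, but every measured exchange at this position, whether to tert-butyl, to the sulfonamide-bearing chain or to 4-methoxyphenyl, stayed within the scatter. On that basis no step beyond the scatter is expected in this assay; the expected step is a 1.0-fold higher number from compound 3 to compound 4 (0.02 log units; within the scatter). Compound 4 is therefore estimated to give 17000 nM, with the estimate spanning 8000 nM to 36000 nM.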

Compound 4, half-maximal inhibitory concentration: > 100000 nM
Compound 4 ended at the assay's limit (the forecaster's own chance of this, stated with the estimate: 5%); at least 5.8-fold (0.76 log units) between middle value and limit.
By their numbers in this assay, from the lowest: compounds 3, 1 and 2 (each within the scatter of the next). At a limit, above all of these: compound 4.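

In this assay, compound 4 stands at a limit of the assay and not at a measured number: the limit of > 100000 nM in this assay, at which 1 of the 4 values shown sits.

Exchanging 4-methoxyphenyl for 2-methoxyphenyl, with the same atoms joined differently, gives an at least 6.0-fold higher number from compound 3 to compound 4 (0.78 log units; beyond the scatter). Compound 4 also separates from the other two compounds, with an at least 5.4-fold higher number from compound 1 to compound 4 (0.73 log units; beyond the scatter) and an at least 4.0-fold higher number from compound 2 to compound 4 (0.60 log units; beyond the scatter), so this position responds to where one methoxy group sits on the phenyl ring, although tert-butyl, the sulfonamide-bearing chain and 4-methoxyphenyl could not be told apart.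

The compounds shown leave open whether a 2-methylphenyl or a 2-hydroxyphenyl group in the same place would also end at a limit, or whether this result is tied to the methoxy group itself. They also give no explanation for the difference between the two methoxyphenyl groups.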